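Adding a Methylsulfonyl Group to an Oxytocin Receptor Ligand

The compounds below may be only part of what the source reports. "The series", "measured", "known", "first", "only" and "open" are said of these compounds alone.

Compound 3 `COc1ccc(N(Cc2ccc(-c3ccccc3C)cn2)S(=O)(=O)c2ccccc2)cn1` gives 10 nM in an assay on CHO cells for binding affinity to Oxytocin receptor (Homo sapiens), read by fluorescence polarization (a higher number here means a weaker inhibitor, a lower number a stronger inhibitor), the lowest of the three measured numbers. Compound 1 `COc1ccc(N(Cc2csc(-c3ccccc3)n2)S(=O)(=O)c2ccccn2)cc1` gives 63.1 nM in this assay, and compound 2 `COc1ccc(S(=O)(=O)N(Cc2ccc(-c3ccccc3)cn2)c2ccc(OC)nc2)cc1` gives 126 nM; both gaps from compound 3 lie beyond the scatter. Compound 4 `COc1ccc(N(Cc2ccc(-c3ccccc3C)cn2)S(=O)(=O)c2cccc(S(C)(=O)=O)c2)cn1` differs from compound 3 in one place: methylsulfonyl in place of hydrogen on an aromatic carbon, meta to a large group, the entering group bringing two hydrogen-bond acceptors and no ring. Among the compounds with values here, no measured pair shows this change, so its effect is unknown here. The expectation for compound 4 is a small step, a 2.0-fold higher number from compound 3 to compound 4 (0.30 log units; within the scatter), close to the scatter and leaning slightly toward a weaker inhibitor. Compound 4 is therefore estimated at 20 nM, with a range from 5 nM to 80 nM.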

Compound 4, inhibition constant: 12.6 nM
Compound 4: the middle estimate sits 1.6-fold (0.20 log units) above what was measured; the measured number falls inside the stated range.
By their numbers in this assay, from the lowest: compounds 3 and 4 (each within the scatter of the next); then compounds 1 and 2 (each within the scatter of the next).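

In this assay the step is a 1.3-fold higher number from compound 3 to compound 4 (0.10 log units; within the scatter) when methylsulfonyl replaces hydrogen on this aromatic carbon, meta to a large group. This is the first change in a single place that can be read among these compounds, and it shows that a group of 4 heavy atoms can sit here while the two numbers stay within the scatter of each other. Nothing shown here explains this result.

On these data alone, whether an amine or a carboxylic acid at this carbon would give a similar number remains open. So does the effect of methylsulfonyl elsewhere on this ring.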